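The compounds below may be only part of what the source reports. "The series", "measured", "known", "first", "only" and "open" are said of these compounds alone.

The account begins with compound 1 `CCCCC(=O)NC(=S)Nc1nc2cc(N)ccc2s1`, which in a functional assay on HeLa cells (Homo sapiens) for cytotoxicity, read by MTT assay, with a stated time of 24 h (a lower number here means a stronger inhibitor, a higher number a weaker inhibitor), gives "not determined" (no result reported), so it has no place of its own on the numbers shown. Its relatives compound 2 `Nc1ccc2sc(NC(=S)NC(=O)c3cccs3)nc2c1` and compound 3 `Nc1ccc2sc(NC(=S)NC(=O)c3ccccc3)nc2c1` have been measured: in this assay compound 2 gives 56100 nM and compound 3 gives 70100 nM, and the move between them is a 1.2-fold higher number from compound 2 to compound 3 (0.10 log units; within the scatter). The step from compound 1 to compound 4 `CCCCC(=O)NC(=S)Nc1nc2ccccc2s1` is a different one: hydrogen in place of amino on an aromatic carbon. Among the measured compounds shown here, no measured step shows this change, and the one recorded step concerns another part of the shared core, so no direction beyond the scatter can be drawn from it. Compound 4 is therefore expected to sit near the measured pair, at an estimated 60000 nM with a range from 15000 nM to 250000 nM.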

Compound 4, half-maximal inhibitory concentration: 56700 nM
The estimate for compound 4 lay 1.1-fold (0.02 log units) above the measured number; low and high end bracket the measured number.
By their numbers in this assay, from the lowest: compounds 2, 4 and 3 (each within the scatter of the next).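

In this assay, among the compounds shown here, compound 1 gives "not determined" (no result reported) and so no step from it to compound 4 can be read. What the amino group adds or takes away in this assay stays open, and nothing shown speaks to a cause.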